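The source may report more compounds than this note shows. Statements on the series, on what has been measured and on what is new or still open speak of the compounds shown alone.

Compound 3 `O=C(O)Cc1sc(C(c2ccc(F)cc2)c2ccc(F)cc2)nc1-c1ccnc(O)c1` gives 890 nM in an in vitro functional assay on HEK285-7 cells for antagonist activity at prostaglandin D2 receptor 2 (Homo sapiens), read by BRET and beta-arrestin recruitment (a higher number here means a weaker inhibitor, a lower number a stronger inhibitor), the highest of the three numbers; compound 1 `CS(=O)(=O)Nc1cccc(-c2nc(C(c3ccc(F)cc3)c3ccc(F)cc3)sc2CC(=O)O)c1` gives 370 nM and compound 2 `O=C(O)Cc1sc(C(c2ccc(F)cc2)c2ccc(F)cc2)nc1-c1ccnc(F)c1` gives 4.7 nM. Compound 4 `O=C(O)Cc1sc(C(c2ccc(F)cc2)c2ccc(F)cc2)nc1-c1ccnc(N2CCC2)c1` differs from compound 3 by azetidin-1-yl in place of hydroxy on an aromatic carbon. For the measured compounds named here, two measured steps bear on this change. The step of a 190-fold higher number from compound 2 to compound 3 (2.28 log units; beyond the scatter) shows how much the hydroxy group at this position cost when it replaced fluoro, and a 2.4-fold higher number from compound 1 to compound 3 (0.38 log units; beyond the scatter) shows a smaller cost against the methanesulfonamido phenyl. Going by the values given here, compound 4 takes the hydroxy group and its donor away, so a large drop in the number is expected, though no azetidinyl compound has been measured and the estimate is therefore wide. Compound 4 is expected to give 30 nM, in a range from 5 nM to 200 nM. The expected step is a 30-fold lower number from compound 3 to compound 4 (1.47 log units; beyond the scatter).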

Compound 4, half-maximal inhibitory concentration: > 100000 nM
Compound 4: only a limit was reported; the forecaster's own chance of this, stated with the estimate: 0%; middle value at least 3300-fold (3.52 log units) from the limit.
By their numbers in this assay, from the lowest: compound 2; then compound 1; then compound 3. At a limit, above all of these: compound 4.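

Compound 4 has no exact number, only a limit: the limit of > 100000 nM in this assay, at which 1 of the 4 values shown sits. Replacing hydroxy with azetidin-1-yl next to the ring nitrogen removes the hydrogen-bond donor, yet the number does not fall: the result is an at least 110-fold higher number from compound 3 to compound 4 (2.05 log units; beyond the scatter). Against fluoro at this place the result is an at least 21000-fold higher number from compound 2 to compound 4 (4.32 log units; beyond the scatter), and against the methanesulfonamido phenyl compound it is an at least 270-fold higher number from compound 1 to compound 4 (2.43 log units; beyond the scatter), so a donor's absence alone does not give a strong inhibitor here. From the compounds shown here alone, whether a plain amino group, dimethylamino or methoxy at this carbon would come closer to compound 2 remains open.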